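Swapping Bromo for Chloro: What Compound 4 May Do

The compounds below may be only part of what the source reports. "The series", "measured", "known", "first", "only" and "open" are said of these compounds alone.

Of the compounds shown here, three with a shared core have been tested in a functional assay on NCI-H460 cells (Homo sapiens) for antiproliferative activity, read by MTT assay, with a stated time of 48 h; a higher number here means a weaker inhibitor, a lower number a stronger inhibitor. Compound 1 `COc1cc(-c2cccc3nc(-c4ccccc4)oc23)cc(OC)c1OC` gives 6800 nM. Compound 2 `COc1cc(-c2cccc3nc(-c4ccc(F)cc4)oc23)cc(OC)c1OC` gives 8700 nM. Compound 3 `COc1cc(-c2cccc3nc(-c4ccc(Br)cc4)oc23)cc(OC)c1OC` gives > 25000 nM, which is a limit of the assay and not a number. Compound 3 therefore stands at the limit of > 25000 nM in this assay, at which 1 of the 3 values shown sits.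

Compound 4 `COc1cc(-c2cccc3nc(-c4ccc(Cl)cc4)oc23)cc(OC)c1OC` has not yet been measured. It carries chloro in place of bromo on an aromatic carbon, the same swap read as 4-bromophenyl to 4-chlorophenyl: chloro in place of bromo on an aromatic carbon.

Among the measured compounds shown here, three measured steps bear on this change. Fluoro in place of hydrogen gave a 1.3-fold higher number from compound 1 to compound 2 (0.11 log units; within the scatter). Bromo in place of hydrogen gave an at least 3.6-fold higher number from compound 1 to compound 3 (0.56 log units; beyond the scatter). Bromo in place of fluoro gave an at least 2.8-fold higher number from compound 2 to compound 3 (0.45 log units; beyond the scatter). Chloro is another halogen, so compound 4 is expected to land within the gap shown by an at least 2.8-fold higher number from compound 2 to compound 3 (0.45 log units; beyond the scatter). That points to a modest move toward a lower number, although the limit on compound 3 leaves the true size open.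

The expected change is an at least 1.9-fold lower number from compound 3 to compound 4 (0.28 log units; that floor lies within the scatter). For compound 4 the estimated value is 13000 nM, with an expected range of 6000 nM to 25000 nM.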

Compound 4, half-maximal inhibitory concentration: > 25000 nM
Compound 4: no number, only a limit; the forecaster's own chance of this, stated with the estimate: 25%; middle value at least 1.9-fold (0.28 log units) away from the limit.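

In this assay compound 4 gives > 25000 nM, which is a limit of the assay and not a number, and the chloro compound now shares that ceiling with the bromo compound: the limit of > 25000 nM in this assay, at which 2 of the 4 values shown sit.

Chloro in place of hydrogen gave an at least 3.6-fold higher number from compound 1 to compound 4 (0.56 log units; beyond the scatter), and chloro in place of fluoro gave an at least 2.8-fold higher number from compound 2 to compound 4 (0.45 log units; beyond the scatter), so bromo is no longer the only group at this place that goes with a clear loss of activity. Compound 2 goes against any rule covering all halogens, since fluoro in place of hydrogen gave only a 1.3-fold higher number from compound 1 to compound 2 (0.11 log units; within the scatter), while the swap of chloro for bromo itself cannot be read, as both of its ends are limits.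

As far as these compounds go, how far past the limit compound 3 and compound 4 truly lie stays open, and so does any ordering between them. The compounds shown also leave open whether a group other than a halogen on this same carbon, such as an amine or a nitrile, would match the hydrogen of compound 1, improve on it, or lose activity as chloro and bromo do.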